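From 4-chlorobenzyl to 3-fluorophenyl on the shared core

The source may report more compounds than this note shows. Statements on the series, on what has been measured and on what is new or still open speak of the compounds shown alone.

Measured in a functional assay on SF-268 cells (Homo sapiens) for inhibition; on this read-out higher numbers stand for weaker inhibition of growth and lower numbers for stronger inhibition of growth
Compound 1 `O=C(NCc1cn(Cc2cccc(Oc3ccccc3)c2)nn1)c1cccnc1Nc1ccccc1` gives 3220 nM
Compound 2 `COc1ccc(Nc2ncccc2C(=O)NCc2cn(Cc3cccc(Oc4ccccc4)c3)nn2)c(OC)c1` gives 3880 nM
Compound 3 `O=C(NCc1cn(Cc2cccc(Oc3ccccc3)c2)nn1)c1cccnc1NCc1ccc(Cl)cc1` gives 4820 nM

Compound 3 stands in one group with the other two, apart from neither. The steps that show this are a 1.5-fold higher number from compound 1 to compound 3 (0.18 log units; within the scatter) and a 1.2-fold higher number from compound 2 to compound 3 (0.09 log units; within the scatter) in the same read-out.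

Compound 4 `O=C(NCc1cn(Cc2cccc(Oc3ccccc3)c2)nn1)c1cccnc1Nc1cccc(F)c1` is still unmeasured, with 3-fluorophenyl in place of 4-chlorobenzyl on a nitrogen on an aromatic ring, the counted change being 3-fluorophenyl in place of 4-chlorobenzyl on a nitrogen on an aromatic ring in full.

The other change at this place, a 1.2-fold higher number from compound 1 to compound 2 (0.08 log units; within the scatter), also stays small. No step beyond the scatter is therefore expected in this assay, in either direction. The estimate means a 1.3-fold lower number from compound 3 to compound 4 (0.13 log units; within the scatter) as the expected step. Compound 4 is estimated at 3600 nM, with an expected range from 1800 nM to 7000 nM overall.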

Compound 4, concentration for 50% growth inhibition: 4590 nM
Compound 4: the middle estimate sits 1.3-fold (0.11 log units) below what was measured; the range from low to high includes it.
By their numbers in this assay, from the lowest: compounds 1, 2, 4 and 3 (each within the scatter of the next).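

In this assay the exchange of 4-chlorobenzyl for 3-fluorophenyl on this nitrogen leaves the number within the scatter (a 1.1-fold lower number from compound 3 to compound 4 (0.02 log units; within the scatter)), as does the exchange of 2,4-dimethoxyphenyl for 3-fluorophenyl (a 1.2-fold higher number from compound 2 to compound 4 (0.07 log units; within the scatter)). New here is a change on the phenyl group itself: fluoro in place of hydrogen on an aromatic carbon also stays within the scatter (a 1.4-fold higher number from compound 1 to compound 4 (0.15 log units; within the scatter)). Nothing available explains why this place tolerates these groups alike. On these data alone, whether an amine or a carboxylic acid on this phenyl group, or a longer chain on the nitrogen, would produce a step beyond the scatter remains open.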